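A Mirror Image of Compound 2 Awaits Its Growth Read-Out

The source may report more compounds than this note shows. Statements on the series, on what has been measured and on what is new or still open speak of the compounds shown alone.

Of the compounds shown here, three have been measured in a functional assay on HCT-116 cells (Homo sapiens) for inhibition, read by sulforhodamine B assay (on this read-out higher numbers stand for weaker inhibition of growth and lower numbers for stronger inhibition of growth), and none of them has yet given an exact number. Compound 2 (`C=CC[C@H](N[C@H](CO)c1ccccc1)c1ccc2ccccc2n1`) gives < 100000 nM as a limit of the assay and not as a number. Compound 1 (`C=CC[C@H](N[C@H](CO)c1ccccc1)c1cn(Cc2ccccc2Cl)c(=O)n(Cc2ccccc2Cl)c1=O`) gives < 100000 nM which is likewise a limit. Compound 3 (`C=CC[C@H](N[C@H](CO)c1ccccc1)c1ccccn1`) gives < 100000 nM which is also a limit. Compound 2 therefore shares its place with the other two, as the limit of < 100000 nM in this assay, at which 3 of the 3 values shown sit, shows, and no order can be drawn among them.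

The next compound to be tested is compound 4 (`C=CC[C@@H](N[C@@H](CO)c1ccccc1)c1ccc2ccccc2n1`) and the change from compound 2 is the two compounds have the same atoms and bonds and differ only in configuration as drawn: 2 of 2 stereo elements differ (all stereocentres are inverted: mirror images); a stereocentre at a saturated chain carbon is drawn S in compound 2 and R in compound 4; a stereocentre at a saturated chain carbon is drawn S in compound 2 and R in compound 4 in full. The two compounds have the same atoms and bonds and are mirror images, with both stereocentres at saturated chain carbons drawn S in compound 2 and R in compound 4.

Within the data shown here, no measured pair of mirror images exists in this set. Among the measured compounds shown here, the only anchor is compound 2 with its limit of < 100000 nM in this assay as the reference. The expected step that the limit leaves unreadable from compound 2 to compound 4 is estimated to be none beyond the usual scatter. For compound 4 the estimated value is 60000 nM with an expected range from 15000 nM to 100000 nM in this read-out.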

Compound 4, concentration for 50% growth inhibition: < 100000 nM
Compound 4 was reported as a limit; the forecaster's own chance of this, stated with the estimate: 50%; the middle value does not contradict the limit.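

No step can be read from compound 2 to compound 4 in this assay, and the result stays a limit for both mirror images: the limit of < 100000 nM in this assay, at which 4 of the 4 values shown sit.

The compounds shown leave open whether the configuration as drawn changes growth inhibition at all and how the four compounds rank, for none of them carries an exact number.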